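Hydroxymethyl for fluoro on a pyrazole acid antagonist

The source may report more compounds than this note shows. Statements on the series, on what has been measured and on what is new or still open speak of the compounds shown alone.

Measured so far:
compound 1 `Cc1cc(C(=O)O)nn1Cc1cc(Br)ccc1OCc1ccccc1`, 15.1 nM
compound 2 `O=C(O)c1nn(Cc2cc(Br)ccc2OCc2ccccc2)cc1F`, 692 nM

In a functional assay on CHO-K1 cells for antagonist activity at prostaglandin E2 receptor EP1 subtype (Homo sapiens), read by FLIPR (a higher number here means a weaker inhibitor, a lower number a stronger inhibitor), compound 1 gives 15.1 nM, and compound 2 gives 692 nM. Among the measured compounds shown here, compound 2 therefore stands with the higher of the two numbers, and the gap to compound 1 lies beyond the scatter; the two compounds differ in more than one place, so no single step connects them.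

Compound 3 `O=C(O)c1nn(Cc2cc(Br)ccc2OCc2ccccc2)cc1CO` is the next compound. Relative to compound 2 the change is hydroxymethyl in place of fluoro on an aromatic carbon. For the measured compounds named here, no measured pair shows the effect of this exchange, so the direction rests on no precedent. The author expects a modest step towards a lower number, a 2.3-fold lower number from compound 2 to compound 3 (0.36 log units; beyond the scatter), with wide uncertainty. In this assay compound 3 is estimated at 300 nM, between 60 nM and 1500 nM.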

Compound 3, inhibition constant: < 2000 nM
Compound 3: only a limit was reported (the forecaster's own chance of this, stated with the estimate: 10%); the middle value is on the limit's open side.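

In this assay compound 3 returned only a limit, < 2000 nM. Among the compounds shown here, no step from compound 2 to compound 3 can therefore be read. The compounds shown leave open whether hydroxymethyl in place of fluoro on an aromatic carbon gives a lower or a higher number in this assay.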